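Dropping the Nitro Group: What Compound 4 Should Show

The source may report more compounds than this note shows. Statements on the series, on what has been measured and on what is new or still open speak of the compounds shown alone.

Compound 1 `CNC(=O)c1cc(Oc2ccc(C(=O)/C=C/c3cccc([N+](=O)[O-])c3)cc2)ccn1`: > 50000 nM
Compound 2 `CNC(=O)c1cc(Oc2ccc(C(=O)/C=C/c3ccc(Cl)cc3Cl)cc2)ccn1`: 3990 nM
Compound 3 `CNC(=O)c1cc(Oc2ccc(C(=O)/C=C/c3ccc(F)cc3)cc2)ccn1`: 28500 nM

In a functional assay on MCF7 cells (Homo sapiens) for cytotoxicity, read by MTT assay, with a stated time of 72 h (a higher number here means a weaker inhibitor, a lower number a stronger inhibitor), compound 1 gives no number, only a limit: the limit of > 50000 nM in this assay, at which 1 of the 3 values shown sits. Compound 4 `CNC(=O)c1cc(Oc2ccc(C(=O)/C=C/c3ccccc3)cc2)ccn1` differs from compound 1 by hydrogen in place of nitro on an aromatic carbon. Two measured steps start at compound 1, and both swap the whole 3-nitrophenyl for another ring rather than removing only the nitro: an at least 12-fold lower number from compound 1 to compound 2 (1.09 log units; beyond the scatter), while an at least 1.7-fold lower number from compound 1 to compound 3 (0.24 log units; that floor lies within the scatter). The second, smaller swap is the closer guide, and the 4-fluorophenyl compound 3 gives 28500 nM. Compound 4 is therefore expected near 30000 nM, within 10000 nM to 80000 nM. For compound 4 this amounts to an expected at least 1.6-fold lower number from compound 1 to compound 4 (0.22 log units; that floor lies within the scatter), with a fair chance that only a limit is reported again.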

Compound 4, half-maximal inhibitory concentration: 5960 nM
For compound 4 the middle estimate is 5.0-fold (0.70 log units) above the measured one; the whole stated range lies above it.
By their numbers in this assay, from the lowest: compounds 2 and 4 (each within the scatter of the next); then compound 3. At a limit, above all of these: compound 1.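

In this assay, taking only the nitro off its aromatic carbon gives an at least 8.3-fold lower number from compound 1 to compound 4 (0.92 log units; beyond the scatter), and that step rests on a limit for compound 1: the limit of > 50000 nM in this assay, at which 1 of the 4 values shown sits. Hydrogen in place of fluoro gives a 4.8-fold lower number from compound 3 to compound 4 (0.68 log units; beyond the scatter), so the unsubstituted phenyl ring alone reaches this level. Phenyl in place of 2,4-dichlorophenyl gives a 1.5-fold higher number from compound 2 to compound 4 (0.17 log units; within the scatter), so the two chlorines bring no readable change.

Going by these compounds, whether the loss belongs to nitro itself or to any group at this place stays open, since compound 1 alone carries a group there. An amine or a methoxy group on that carbon would separate the two.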